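From azetidin-1-yl to (2-methoxyphenyl)amino on the shared core

The compounds below may be only part of what the source reports. "The series", "measured", "known", "first", "only" and "open" are said of these compounds alone.

In a functional assay on MGC-803 cells (Homo sapiens) for inhibition, read by sulforhodamine B assay (a lower number here means a stronger inhibitor, a higher number a weaker inhibitor), compound 2 `O=C1C=C(N2CCC2)C(=O)c2c1nc1n2[C@H]2OC[C@@H](O)[C@H]2OC1` reads > 16000 nM, which is a limit and not a number. Compound 3 `O=C1C(NC2CCCC2)=CC(=O)c2c1nc1n2[C@H]2OC[C@@H](O)[C@H]2OC1` reads > 16000 nM, also a limit. Compound 2 thus stands at the limit of > 16000 nM in this assay, at which 2 of the 3 values shown sit. Compound 1 `O=C1C(Nc2ccccc2F)=CC(=O)c2c1nc1n2[C@H]2OC[C@@H](O)[C@H]2OC1` gives a true number, 2000 nM. Compound 4 `COc1ccccc1NC1=CC(=O)c2nc3n(c2C1=O)[C@H]1OC[C@@H](O)[C@H]1OC3` differs from compound 2 by (2-methoxyphenyl)amino in place of azetidin-1-yl on a double-bonded ring carbon, with (2-methoxyphenyl)amino in place of azetidin-1-yl on a double-bonded ring carbon. For the measured compounds named here, compound 4 shares an aromatic ring on an amine nitrogen with compound 1, so the one measured step that bears on it is an at least 8.0-fold higher number from compound 1 to compound 3 (0.90 log units; beyond the scatter), read in reverse. A step of similar size toward a lower number is expected, an at least 5.3-fold lower number from compound 2 to compound 4 (0.72 log units; beyond the scatter). The estimate for compound 4 is 3000 nM, with an expected range of 1000 nM to 10000 nM.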

Compound 4, half-maximal inhibitory concentration: 1630 nM
Compound 4: middle estimate off by 1.8-fold (0.26 log units), on the high side; low and high end bracket the measured number.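

Replacing azetidin-1-yl with (2-methoxyphenyl)amino gives an at least 9.8-fold lower number from compound 2 to compound 4 (0.99 log units; beyond the scatter), a minimum size, since the value of compound 2 is a limit. For the compounds shown here, compound 1 was the only compound with an aromatic ring on the amine nitrogen, and compound 4 shows that a second such group also gives a true number in this assay. Among these four compounds, compound 2 and compound 3, which lack that ring, both sit at the limit, and none goes against this pattern. On these data alone, it remains open whether an unsubstituted phenylamino group, or a phenyl ring carrying a carboxylic acid, would also give a true number.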